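This account rests on a few compounds, and the source may have more. Where it says the series, first, only, none or still open, it means among the compounds named here.

Measured so far in a functional assay on SW 1116 cells (Homo sapiens) for antiproliferative activity, read by MTT assay, with a stated time of 24 h; on this read-out lower numbers stand for stronger inhibition and higher numbers for weaker inhibition:
compound 1 `Clc1ccccc1CSc1nnc(-c2ccc3c(c2)OCCO3)n1-c1ccccc1` gives 9670 nM
compound 2 `Clc1cccc(CSc2nnc(-c3ccc4c(c3)OCCO4)n2-c2ccccc2)c1` gives 10600 nM

Compound 2 (10600 nM) cannot be separated from compound 1 (9670 nM), so the pair gives no order. Compound 3 `Cc1ccccc1CSc1nnc(-c2ccc3c(c2)OCCO3)n1-c1ccccc1` carries 2-methylphenyl in place of 3-chlorophenyl on a saturated chain carbon bound to a sulfur.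

For the measured compounds named here, only one measured step bears on this change: 3-chlorophenyl in place of 2-chlorophenyl at the same place (a 1.1-fold higher number from compound 1 to compound 2 (0.04 log units; within the scatter)). That step stays within the scatter. Going by the values given here, no measured step replaces a chlorophenyl with a methylphenyl, so the support is indirect and rests on two compounds only. In this assay no step beyond the scatter is expected, and the data favour no direction. The expected step is small (a 1.1-fold lower number from compound 2 to compound 3 (0.03 log units; within the scatter)) and the range is kept wide. The estimate for compound 3 is 10000 nM with 4500 nM to 22000 nM as the expected range.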

Compound 3, half-maximal inhibitory concentration: 12700 nM
Beside the measured number, compound 3's estimate is 1.3-fold (0.10 log units) below it, within the range that was stated.
By their numbers in this assay, from the lowest: compounds 1, 2 and 3 (each within the scatter of the next).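

In this assay, the change of 2-methylphenyl for 3-chlorophenyl on a saturated chain carbon bound to a sulfur gives a 1.2-fold higher number from compound 2 to compound 3 (0.08 log units; within the scatter), and methyl in place of chloro on an aromatic carbon gives a 1.3-fold higher number from compound 1 to compound 3 (0.12 log units; within the scatter). The earlier pair only compared two chlorophenyl groups, whereas these steps show that, across the three compounds, replacing chloro with methyl on this ring does not separate the numbers in this assay. No supporting measurement bears on this result, so the flat reading stands without an explanation.

Open is whether any group at this place can move the number in this assay beyond the scatter, since the compounds shown carry only a single chloro or methyl on the phenyl ring. A carboxylic acid or an amine on that ring, or a longer chain between the sulfur and the ring in place of the 2-methylbenzyl, would test how far this flat reading extends.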